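A few compounds are considered here, and "the series" means these few. Any claim that something is new, unique, unknown or untested is made for them only; others in the source may bear on it.

Measured so far:
- Compound 1 `CCCCCNc1cnc(C(=O)NCc2ccccc2)cn1`: > 100000 nM
- Compound 2 `CCCCCCCCNc1cncc(C(=O)NCc2ccccc2)n1`: > 100000 nM

In an ADME assay on Vero cells (Chlorocebus sabaeus) for cytotoxicity, read by microscopy, with a stated time of 6 days (on this read-out lower numbers stand for higher toxicity in this test and higher numbers for lower toxicity in this test), compound 2 gives > 100000 nM, which is a limit of the assay rather than a measured number. Compound 1 gives > 100000 nM in the same test, again a limit. For the measured compounds named here, the shared picture is therefore (the limit of > 100000 nM in this assay, at which 2 of the 2 values shown sit), so nothing among the measured compounds separates one from the other, and no step between them can be sized. Compound 3 `CCCCCNc1cncc(C(=O)NCc2ccccc2)n1` is the next compound to be tested. It differs from compound 2 by hydrogen in place of propyl on a saturated chain carbon, five bonds along the chain from a nitrogen on an aromatic ring. Since both measured compounds sit at the limit, the only reasonable expectation is that compound 3 stays in the same region, with a step that the limit leaves unreadable from compound 2 to compound 3 that is expected to be nothing beyond the usual scatter. For compound 3 the estimated value in this assay is 150000 nM, with an expected range from 50000 nM to 400000 nM.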

Compound 3, minimum cytotoxic concentration: > 100000 nM
Compound 3: no number, only a limit; the forecaster's own chance of this, stated with the estimate: 80%; the middle value is on the limit's open side.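

In this assay, for the compounds shown here, compound 3 gives > 100000 nM, which is a limit and not a number, so no step from compound 2 to compound 3 can be read. The same holds across the set: the limit of > 100000 nM in this assay, at which 3 of the 3 values shown sit. The compounds shown leave open at what concentration compound 1, compound 2 or compound 3 would harm these cells, and whether those concentrations differ.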